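From one ring fluorine to four: an estimate

This account rests on a few compounds, and the source may have more. Where it says the series, first, only, none or still open, it means among the compounds named here.

Compound 1 `CC(C)[C@H](NC(=O)COc1cccc2ccccc12)C(=O)N[C@@H](CC(=O)O)C(=O)COc1cccc2ccccc12`: in a functional assay on Jurkat cells (Homo sapiens) (on this read-out lower numbers stand for stronger inhibition and higher numbers for weaker inhibition), compound 1 gives > 100000 nM, a limit of the assay.
Compound 2 `CC(C)[C@H](NC(=O)COc1cccc2ccccc12)C(=O)N[C@@H](CC(=O)O)C(=O)COc1ccc(C(F)(F)F)cc1`: in this assay compound 2 gives > 100000 nM, likewise a limit.
Compound 3 `CC(C)[C@H](NC(=O)COc1cccc2ccccc12)C(=O)N[C@@H](CC(=O)O)C(=O)COc1cccc(F)c1`: in this assay compound 3 gives > 100000 nM, also a limit.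

Compound 3 thus stands at the assay limit, as do the two other values shown (the limit of > 100000 nM in this assay, at which 3 of the 3 values shown sit). The steps a step that the two limits leave unreadable from compound 1 to compound 3 and a step that the two limits leave unreadable from compound 2 to compound 3 therefore cannot be read in size or direction. Compound 4 `CC(C)[C@H](NC(=O)COc1cccc2ccccc12)C(=O)N[C@@H](CC(=O)O)C(=O)COc1c(F)c(F)cc(F)c1F` differs from compound 3 by 2,3,5,6-tetrafluorophenyl in place of 3-fluorophenyl on an oxygen on a saturated carbon. For the measured compounds named here, no measured step tells how far a change at this oxygen on a saturated carbon can move the read-out. The step of a number no higher from compound 3 to compound 4 (the limit leaves the size open) is expected to be nil beyond the scatter. Compound 4 is expected at 100000 nM, with a range from 30000 nM to 300000 nM, most likely reported again only as a limit.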

Compound 4, half-maximal inhibitory concentration: 4500 nM
Beside the measured number, compound 4's estimate is 22-fold (1.35 log units) above it; the whole stated range lies above it.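

The group on the oxygen on a saturated carbon can move the read-out in this assay after all: 2,3,5,6-tetrafluorophenyl gives an at least 22-fold lower number from compound 3 to compound 4 (1.34 log units; beyond the scatter), and likewise an at least 22-fold lower number from compound 2 to compound 4 (1.34 log units; beyond the scatter) and an at least 22-fold lower number from compound 1 to compound 4 (1.34 log units; beyond the scatter). The steps among compound 1, compound 2 and compound 3 cannot be read, and compound 4 alone gives a number rather than a limit: the limit of > 100000 nM in this assay, at which 3 of the 4 values shown sit.

From the compounds shown here alone, it remains open whether the count of ring fluorines or their places carry this step. Also open, going by these compounds, is how pentafluorophenyl or a nitrile-bearing phenyl on the same oxygen would read.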